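Removing the amino ester from compound 2

A few compounds are considered here, and "the series" means these few. Any claim that something is new, unique, unknown or untested is made for them only; others in the source may bear on it.

In a functional assay on HCT-116 cells (Homo sapiens) for inhibition, read by fluorescence, with a stated time of 48 h (a higher number here means a weaker inhibitor of growth, a lower number a stronger inhibitor of growth), compound 2 (`CC(C)(COC(=O)[C@@H](N)c1ccccc1)COC1(c2ccc(Cl)cc2)c2ccccc2C(=O)N1Cc1ccccc1`) gives 15000 nM, compound 1 (`N[C@H](C(=O)OCCCOC1(c2ccc(Cl)cc2)c2ccccc2C(=O)N1Cc1ccccc1)c1ccccc1`) gives 14000 nM and compound 3 (`N[C@H](C(=O)OCCCOC1(c2ccc(Cl)cc2)c2ccccc2C(=O)N1Cc1ccc(Cl)cc1)c1ccccc1`) gives 12000 nM. These three values lie within the scatter of one another.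

The next structure is compound 4 (`CC(C)(CO)COC1(c2ccc(Cl)cc2)c2ccccc2C(=O)N1Cc1ccccc1`). The change from compound 2 is hydrogen in place of (amino(phenyl)methyl)carbonyl on an oxygen on a saturated carbon, leaving a hydroxymethyl.

Among the measured compounds shown here, the only measured single-place step, a 1.2-fold lower number from compound 1 to compound 3 (0.07 log units; within the scatter), is chloro in place of hydrogen on an aromatic carbon. It stays within the scatter and bears only indirectly on this change. All three measured compounds keep the (amino(phenyl)methyl)carbonyl group, so no measurement tests its removal. For the measured compounds named here, the expectation therefore rests on the flat values so far, and it is uncertain: no shift beyond the scatter is expected in this assay.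

The expected change is a 1.2-fold higher number from compound 2 to compound 4 (0.08 log units; within the scatter). For compound 4 the estimate is 18000 nM, with an expected range from 7000 nM to 45000 nM.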

Compound 4, concentration for 50% growth inhibition: 71000 nM
For compound 4 the middle estimate is 3.9-fold (0.60 log units) below the measured one; the whole stated range lies below it.
By their numbers in this assay, from the lowest: compounds 3, 1 and 2 (each within the scatter of the next); then compound 4.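

In this assay, among the compounds shown here, the loss of the (amino(phenyl)methyl)carbonyl group, leaving a hydroxymethyl, gives a 4.7-fold higher number from compound 2 to compound 4 (0.68 log units; beyond the scatter) and is the first step to pass the scatter. The earlier compounds shown here all keep this group and stay flat, so only now is it clear that growth inhibition is sensitive to what sits on this oxygen, although the step is modest. No evidence at hand accounts for the step.

Going by these compounds, the whole group leaves in one change, so the share of its amine and of its phenyl ring remains open. A plain acetyl ester or an aminoacetyl ester on the same oxygen would separate the two, and would show whether any ester there matches compound 2.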